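Swapping Trimethoxyphenyl for Phenyl at the Carbonyl

A few compounds are considered here, and "the series" means these few. Any claim that something is new, unique, unknown or untested is made for them only; others in the source may bear on it.

Three analogues on a shared core were examined in a functional assay on DU-145 cells (Homo sapiens) for antiproliferative activity, read by MTT assay, with a stated time of 24 h; on this read-out higher numbers stand for weaker inhibition and lower numbers for stronger inhibition. Compound 1 `COc1ccc(-c2cc(/C=C/C(=O)c3cc(OC)c(OC)c(OC)c3)nc3cc(-c4ccccc4)nn23)cc1OC` gives 8300 nM, the lowest of the three numbers. Compound 3 `COc1cc(-c2cc(/C=C/C(=O)c3ccc(C)c(C)c3)nc3cc(-c4ccccc4)nn23)cc(OC)c1OC` gives 15400 nM, which sits within the usual scatter of compound 1, whereas compound 2 `COc1cc(/C=C/C(=O)c2cc(-c3cc(OC)c(OC)c(OC)c3)n3nc(-c4ccccc4)cc3n2)cc(OC)c1OC` gives 17900 nM, a gap beyond the scatter. No pair among these three differs in a single place, so no measured step is available.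

Compound 4 `COc1ccc(-c2cc(/C=C/C(=O)c3ccccc3)nc3cc(-c4ccccc4)nn23)cc1OC` is the untested analogue; it differs from compound 1 by phenyl in place of 3,4,5-trimethoxyphenyl on a carbonyl carbon. Because compound 1 gives 8300 nM with the 3,4,5-trimethoxyphenyl present, only a small step toward a higher number, perhaps not beyond the scatter, is expected: a 1.4-fold higher number from compound 1 to compound 4 (0.16 log units; within the scatter). Compound 4 is therefore estimated at 12000 nM, with a range from 5000 nM to 30000 nM.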

Compound 4, half-maximal inhibitory concentration: 10000 nM
Compound 4: middle estimate off by 1.2-fold (0.08 log units), on the high side, and the stated range covers the measured number.
By their numbers in this assay, from the lowest: compounds 1, 4, 3 and 2 (each within the scatter of the next, the first and the last beyond it).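

In this assay, going by these compounds alone, the result gives the first measured step at this position: phenyl in place of 3,4,5-trimethoxyphenyl on a carbonyl carbon gives a 1.2-fold higher number from compound 1 to compound 4 (0.08 log units; within the scatter) and so stays within the scatter. In this pair, the three methoxy groups can therefore go without a change that can be told from the scatter. Nothing measured here bears on why this is so.

From the compounds shown here alone, it remains open whether a carboxylic acid or an amine on that phenyl would move the number beyond the scatter. Going by these compounds, whether the step holds with other groups elsewhere on the shared core is also open.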